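The source may hold more compounds than are shown below. What is called first, only, known or untested is meant among the compounds shown, and "the series" means these compounds.

The measured compounds are three. Compound 1, `COc1ncc(-c2ccc3c(c2)N(c2ccc(C)cc2)C(=O)CO3)cc1NS(=O)(=O)c1ccc(F)cc1`, gives 12900 nM in a functional assay on A-375 cells (Homo sapiens) for antiproliferative activity, read by MTT assay, with a stated time of 72 h; a higher number here means a weaker inhibitor, a lower number a stronger inhibitor. Compound 2, `COc1ccc(N2C(=O)COc3ccc(-c4cnc(OC)c(NS(=O)(=O)c5ccc(F)cc5)c4)cc32)cc1`, gives 18400 nM in this assay. Compound 3, `O=C1COc2ccc(-c3cnc(Cl)c(NS(=O)(=O)c4ccc(F)cc4)c3)cc2N1c1ccc(F)cc1`, gives only a limit in this assay, namely > 40000 nM.

Going by the values given here, compound 3 therefore stands at the edge of what this assay reports: its result is the limit of > 40000 nM in this assay, at which 1 of the 3 values shown sits, a limit and not a number, so no step from it can be sized from the data.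

Compound 4, `COc1ncc(-c2ccc3c(c2)N(c2ccc(F)cc2)C(=O)CO3)cc1NS(=O)(=O)c1ccc(F)cc1`, differs from compound 3 by methoxy in place of chloro on an aromatic carbon. Among the compounds with values here, no measured step alters this position. The only measured step, a 1.4-fold higher number from compound 1 to compound 2 (0.15 log units; within the scatter), concerns a different aromatic carbon and lies within the scatter, so the group there appears to matter little among these compounds. Compound 4 carries the same methoxy as compounds 1 and 2 and differs from each of them only at that other aromatic carbon. Its value in this assay is therefore expected to fall near those of compounds 1 and 2 rather than at the limit of compound 3.

Compound 4 is expected to give about 16000 nM, with a range from 6000 nM to 40000 nM. This estimate means an expected step of an at least 2.5-fold lower number from compound 3 to compound 4 (0.39 log units; beyond the scatter), measured against a limit rather than a number.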

Compound 4, half-maximal inhibitory concentration: > 40000 nM
Compound 4 ended at the assay's limit (the forecaster's own chance of this, stated with the estimate: 25%); middle value at least 2.5-fold (0.39 log units) away from the limit.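

Methoxy in place of chloro on the aromatic carbon next to the ring nitrogen leaves the reading at the limit of the assay, so the step from compound 3 cannot be read and neither group can be ranked over the other while fluoro sits on the other aromatic carbon: the limit of > 40000 nM in this assay, at which 2 of the 4 values shown sit. With the methoxy held, that other carbon now proves to count, since fluoro in place of methoxy gives an at least 2.1-fold higher number from compound 2 to compound 4 (0.33 log units; beyond the scatter) and fluoro in place of methyl gives an at least 3.1-fold higher number from compound 1 to compound 4 (0.49 log units; beyond the scatter). Methoxy and methyl at that carbon had differed only within the scatter, so the earlier compounds gave the impression that the group there mattered little in this assay, and this holds for those two groups only, not for fluoro.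

From the compounds shown here alone, every compound with a readable value carries methoxy on the carbon next to the ring nitrogen, so how chloro reads with methyl or methoxy on the other aromatic carbon stays open. The compounds shown also leave open how an amine or an ethoxy group would read in place of that methoxy, and how a chloro or a trifluoromethyl group would read in place of the fluoro of compound 4.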